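This account rests on a few compounds, and the source may have more. Where it says the series, first, only, none or still open, it means among the compounds named here.

Compound 1 `CCOc1ccc(C(=O)/C=C/c2c(/C=C/c3ccc(OC)cc3)cc(OC)cc2OC)cc1` gives 7.5 ug/mL in a functional assay on A549 cells (Homo sapiens) for antiproliferative activity, read by MTT assay, with a stated time of 48 h (on this read-out lower numbers stand for stronger inhibition and higher numbers for weaker inhibition), and stands second highest of the three numbers at hand. Nearest is compound 2 `COc1ccc(/C=C/c2cc(OC)cc(OC)c2/C=C/C(=O)c2ccc(C(F)(F)F)cc2)cc1` with 7.8 ug/mL; furthest is compound 3 `COc1ccc(/C=C/c2cc(OC)cc(OC)c2/C=C/C(=O)c2ccc(C)cc2C)cc1` with 0.3 ug/mL. Compound 4 `COc1ccc(/C=C/c2cc(OC)cc(OC)c2/C=C/C(=O)c2ccc(Cl)cc2)cc1` differs from compound 1 by chloro in place of ethoxy on an aromatic carbon. Of the measured steps, a 1.0-fold higher number from compound 1 to compound 2 (0.02 log units; within the scatter) also exchanges one group for another on an aromatic carbon and stays within the scatter, whereas a 25-fold lower number from compound 1 to compound 3 (1.40 log units; beyond the scatter) and a 26-fold lower number from compound 2 to compound 3 (1.41 log units; beyond the scatter) exchange the whole ring on the carbonyl carbon and are large. The change to compound 4 is of the first kind, so no step beyond the scatter is expected in this assay in either direction. Compound 4 is therefore estimated at 6 ug/mL, between 2.5 ug/mL and 15 ug/mL. The expected step of a 1.3-fold lower number from compound 1 to compound 4 (0.10 log units; within the scatter) stays within the scatter.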

Compound 4, half-maximal inhibitory concentration: 6.4 ug/mL
Estimate against measurement, compound 4: 1.1-fold (0.03 log units) below; the measured number falls inside the stated range.
By their numbers in this assay, from the lowest: compound 3; then compounds 4, 1 and 2 (each within the scatter of the next).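

In this assay chloro on this aromatic carbon gives a 1.2-fold lower number from compound 1 to compound 4 (0.07 log units; within the scatter) and a 1.2-fold lower number from compound 2 to compound 4 (0.09 log units; within the scatter), so ethoxy, trifluoromethyl and chloro at this place cannot be told apart. Going by these compounds alone, the only step beyond the scatter involving compound 4 is a 21-fold higher number from compound 3 to compound 4 (1.33 log units; beyond the scatter), which exchanges the whole ring on the carbonyl carbon for 2,4-dimethylphenyl and leaves that ring as the one change here that separates compounds. No measured evidence bears on the reason for this pattern.

Still open, on these data alone, is whether an amine or a carboxylic acid at this place would also stay within the scatter. Also open, as far as these compounds go, is whether the low number of compound 3 needs both methyl groups of its 2,4-dimethylphenyl ring.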